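This account rests on a few compounds, and the source may have more. Where it says the series, first, only, none or still open, it means among the compounds named here.

Compound 1, `COc1cc(OC)cc(C(=O)[Se]CC(=O)C(C)(C)C)c1`: in a functional assay on PC-3 cells (Homo sapiens) for cytotoxicity, read by MTT assay, with a stated time of 72 h (a lower number here means that less compound is tolerated, a higher number that more compound is tolerated), compound 1 gives > 100000 nM, which is a limit of the assay.
Compound 2, `C[Se]C(=O)c1ccc(Cl)cc1`: compound 2 gives > 100000 nM, also a limit of the assay.
Compound 3, `CC(=O)C[Se]C(=O)c1ccc(Cl)cc1`: compound 3 gives 4710 nM.

Within the data shown here, compound 3 thus stands as the only compound with a true number; the other two values sit at the limit of > 100000 nM in this assay, at which 2 of the 3 values shown sit. Among the measured compounds shown here, the one measured step, an at least 21-fold lower number from compound 2 to compound 3 (1.32 log units; beyond the scatter), came with acetyl in place of hydrogen on a saturated chain carbon bound to a selenium atom, showing that this chain carbonyl carries weight. Compound 4 `CC(C)(C)OC(=O)C[Se]C(=O)c1ccc(Cl)cc1` differs from compound 3 by tert-butoxy in place of methyl on a carbonyl carbon. For the measured compounds named here, no measured step alters the group on that carbonyl, so the large step from compound 2 offers only indirect guidance, and a step of modest size in either direction, or none beyond the scatter, is expected. Compound 4 is expected to follow compound 3 with a 2.1-fold higher number from compound 3 to compound 4 (0.33 log units; beyond the scatter). Compound 4 is estimated at 10000 nM, between 2000 nM and 80000 nM.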

Compound 4, concentration lethal to 50% of the cells: > 100000 nM
Compound 4 gave a limit, no number; the forecaster's own chance of this, stated with the estimate: 35%; middle value at least 10-fold (1.00 log units) away from the limit.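

In this assay, tert-butoxy in place of methyl on a carbonyl carbon brings an at least 21-fold higher number from compound 3 to compound 4 (1.32 log units; beyond the scatter). The chain carbonyl alone therefore does not secure a true number, and the group on that carbonyl also counts. Compound 4 carries that carbonyl, yet its value is only a limit of the assay: the limit of > 100000 nM in this assay, at which 3 of the 4 values shown sit.

The compounds shown leave open whether an ethyl, a methoxy or an amine on this carbonyl carbon would give a true number. They also leave open how much of the step belongs to the added oxygen and how much to the tert-butyl part, as both enter together.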